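A few compounds are considered here, and "the series" means these few. Any claim that something is new, unique, unknown or untested is made for them only; others in the source may bear on it.

For the measured compounds named here, compound 1 `O=c1ccc(-c2ccc3cn[nH]c3c2)cn1Cc1cccc(C(F)(F)F)c1` gives 32 nM in an assay for inhibition of MAP kinase-interacting serine/threonine-protein kinase 2 (Homo sapiens), read by luminescence and ADP-Glo, with a stated time of 2 h (on this read-out lower numbers stand for stronger inhibition and higher numbers for weaker inhibition), the highest of the three numbers measured so far. Compound 2 `Nc1n[nH]c2cc(-c3ccc(=O)n(Cc4cccc(F)c4)c3)ccc12` gives 5 nM and compound 3 `Nc1n[nH]c2cc(-c3ccc(=O)n(Cc4cccc(C(F)(F)F)c4)c3)ccc12` gives 21 nM; the step of a 1.5-fold lower number from compound 1 to compound 3 (0.18 log units; within the scatter) lies within the scatter, whereas a 4.2-fold higher number from compound 2 to compound 3 (0.62 log units; beyond the scatter) lies beyond it. Compound 4 `NC(=O)c1cccc(Cn2cc(-c3ccc4cn[nH]c4c3)ccc2=O)c1` differs from compound 1 by carbamoyl in place of trifluoromethyl on an aromatic carbon. Going by the values given here, no measured step exchanges trifluoromethyl for carbamoyl. Among the compounds with values here, the only step touching that group is a 4.2-fold higher number from compound 2 to compound 3 (0.62 log units; beyond the scatter), in which the trifluoromethyl compound carried the higher number, so the change away from trifluoromethyl is expected to bring a modest move toward a lower number, estimated as a 1.8-fold lower number from compound 1 to compound 4 (0.25 log units; within the scatter). Compound 4 is therefore expected to give about 18 nM, in a range from 6 nM to 60 nM.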

Compound 4, half-maximal inhibitory concentration: 106 nM
Estimate against measurement, compound 4: 5.9-fold (0.77 log units) below, outside the stated range (above it).
By their numbers in this assay, from the lowest: compound 2; then compounds 3 and 1 (each within the scatter of the next); then compound 4.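

In this assay, carbamoyl in place of trifluoromethyl gives a 3.3-fold higher number from compound 1 to compound 4 (0.52 log units; beyond the scatter), so moving away from trifluoromethyl at this place does not by itself bring a lower number. For the compounds shown here, the only earlier change here, between fluoro and trifluoromethyl on the amino-bearing compounds, had trifluoromethyl carrying the higher number. Nothing available explains the difference between these two changes. Going by these compounds, whether carbamoyl would give a similar step on compound 3 remains open, as does how a nitrile or a carboxylic acid would read at this place.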